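Combining Two Substituent Swaps on a Shared Core

The compounds below may be only part of what the source reports. "The series", "measured", "known", "first", "only" and "open" are said of these compounds alone.

Compound 1 `CC(C)c1ccc(-c2nc(SCc3cn(CC(=O)NC(=O)Nc4ccccn4)nn3)nc(Nc3cccc(C(F)(F)F)c3)c2C#N)cc1` serves as the reference point. In a functional assay on B16-F10 cells (Mus musculus) for inhibition, read by MTT assay, with a stated time of 72 h (on this read-out lower numbers stand for stronger inhibition and higher numbers for weaker inhibition), compound 1 gives 1700 nM. Compound 2 `CC(C)c1ccc(Nc2nc(SCc3cn(CC(=O)NC(=O)Nc4ccccn4)nn3)nc(-c3ccc(C(C)C)cc3)c2C#N)cc1` differs from compound 1 by 4-isopropylphenyl in place of 3-(trifluoromethyl)phenyl on a nitrogen on an aromatic ring; in this assay compound 2 gives 4380 nM, which amounts to a 2.6-fold higher number from compound 1 to compound 2 (0.41 log units; beyond the scatter). Compound 3 `N#Cc1c(Nc2cccc(C(F)(F)F)c2)nc(SCc2cn(CC(=O)NC(=O)Nc3ccccn3)nn2)nc1-c1ccc(Br)cc1` differs from compound 1 by bromo in place of isopropyl on an aromatic carbon; in this assay compound 3 gives 4550 nM, a step of a 2.7-fold higher number from compound 1 to compound 3 (0.43 log units; beyond the scatter). Compound 2 and compound 3 lie within the scatter of each other, so no order between them can be read.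

Compound 4 `CC(C)c1ccc(Nc2nc(SCc3cn(CC(=O)NC(=O)Nc4ccccn4)nn3)nc(-c3ccc(Br)cc3)c2C#N)cc1` has not yet been measured in this assay. It differs from compound 3 by 4-isopropylphenyl in place of 3-(trifluoromethyl)phenyl on a nitrogen on an aromatic ring, the same change that separates compound 1 from compound 2, and the two cores differ by the bromo-for-isopropyl swap already described. Compound 4 is expected to give 10500 nM, with a range from 4500 nM to 25000 nM. This expectation corresponds to a 2.3-fold higher number from compound 3 to compound 4 (0.36 log units; beyond the scatter). It rests on compound 1 and compound 2, where the same change gave a 2.6-fold higher number from compound 1 to compound 2 (0.41 log units; beyond the scatter). Among the measured compounds shown here, the range is kept wide: the change has only one earlier instance, and whether it carries over onto the core of compound 3 is untested.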

Compound 4, half-maximal inhibitory concentration: 42 nM
The estimate for compound 4 lay 250-fold (2.40 log units) above the measured number, and the stated range ends above it.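

In this assay, 4-isopropylphenyl in place of 3-(trifluoromethyl)phenyl gives a 110-fold lower number from compound 3 to compound 4 (2.03 log units; beyond the scatter), so on the core of compound 3 the change runs opposite to its earlier direction and is much larger: the same change on two cores in this assay, a 2.6-fold higher number (0.41 log units; beyond the scatter) from compound 1 to compound 2 and a 110-fold lower number (2.03 log units; beyond the scatter) from compound 3 to compound 4, 280-fold (2.45 log units) apart, beyond the scatter of two such steps. Bromo in place of isopropyl gives a 100-fold lower number from compound 2 to compound 4 (2.02 log units; beyond the scatter), and this change also fails to carry over from one core to the other: the same change on two cores in this assay, a 2.7-fold higher number (0.43 log units; beyond the scatter) from compound 1 to compound 3 and a 100-fold lower number (2.02 log units; beyond the scatter) from compound 2 to compound 4, 280-fold (2.45 log units) apart, beyond the scatter of two such steps. Across these four compounds, the step for either change could not be transferred, since its size and direction depended on the group at the other place, but a single set of four compounds does not show why this is so or whether it holds for other pairs of groups.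

Going by these compounds, it remains open whether the low number of compound 4 is particular to bromo paired with 4-isopropylphenyl. A chloro or methoxy group in place of the bromo, or an unsubstituted phenyl in place of the 4-isopropylphenyl on the nitrogen, would test how narrow that pairing is.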